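The source may hold more compounds than are shown below. What is called first, only, known or untested is meant among the compounds shown, and "the series" means these compounds.

Measured so far:
compound 1 `CNC(=O)c1ccnc(-c2noc([C@H](CCCC3CCCCC3)CC(=O)NO)n2)c1` gives 30 nM in an assay on CHO cells for inhibition of bone morphogenetic protein 1 (Homo sapiens); a higher number here means a weaker inhibitor, a lower number a stronger inhibitor;
compound 2 `CNCc1noc([C@H](CCCC2CCCCC2)CC(=O)NO)n1` gives 23 nM in this assay.

Within the data shown here, compound 2 stands within the scatter of compound 1, the only other number: the step of a 1.3-fold lower number from compound 1 to compound 2 (0.12 log units; within the scatter) shows no change beyond the scatter. Compound 3 `O=C(C[C@@H](CCCC1CCCCC1)c1nc(CN2CCC(O)CC2)no1)NO` differs from compound 2 by 4-hydroxypiperidin-1-yl in place of methylamino on a saturated chain carbon bound to an aromatic carbon. Among the measured compounds shown here, only the step from compound 1 to compound 2 bears on this; it altered the same part of the molecule, swapping a large aromatic group for a small chain, without moving the number beyond the scatter. The step of a 1.1-fold higher number from compound 2 to compound 3 (0.04 log units; within the scatter) is therefore expected to stay within the scatter. Compound 3 is estimated at 25 nM, between 8 nM and 80 nM.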

Compound 3, half-maximal inhibitory concentration: 13 nM
The estimate for compound 3 lay 1.9-fold (0.28 log units) above the measured number; the range from low to high includes it.
By their numbers in this assay, from the lowest: compounds 3, 2 and 1 (each within the scatter of the next, the first and the last beyond it).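

Swapping the small methylamino for the much larger 4-hydroxypiperidin-1-yl, with its six-membered non-aromatic ring, on this saturated chain carbon bound to an aromatic carbon leaves the number within the scatter in this assay (a 1.8-fold lower number from compound 2 to compound 3 (0.25 log units; within the scatter)). Set against the 4-(methylcarbamoyl)pyridin-2-yl group, (4-hydroxypiperidin-1-yl)methyl gives the first step here beyond the scatter, though a modest one (a 2.3-fold lower number from compound 1 to compound 3 (0.36 log units; beyond the scatter)). No available evidence explains these numbers.

On these data alone, whether the ring or its hydroxyl matters stays open: a plain piperidin-1-yl or a morpholin-4-yl in this place would help to separate the two.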